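Carboxy for nitro in a rat whole-animal assay

This account rests on a few compounds, and the source may have more. Where it says the series, first, only, none or still open, it means among the compounds named here.

compound 1 `N#Cc1ccc(C(=O)Nc2ccc(-c3nn[nH]n3)cc2)cc1` gives 2.4 mg/kg
compound 2 `O=C(O)c1cc(NC(=O)c2ccc([N+](=O)[O-])cc2)cc(C(=O)O)c1` gives 9.8 mg/kg
compound 3 `O=C(Nc1cccc(-c2nn[nH]n2)c1)c1cccc(-c2nn[nH]n2)c1` gives 1.6 mg/kg

All three compounds were tested in a functional assay on the whole organism with Rattus norvegicus as the target, at a dose of 25 mg/kg by the intravenous route (a higher number here means that more compound is needed for the effect, a lower number that less compound is needed), and gave a number. Compound 2 stands highest of the three at 9.8 mg/kg and so needs the most compound for the effect. Its distance to each of the other two lies beyond the usual scatter. Compound 1 at 2.4 mg/kg and compound 3 at 1.6 mg/kg lie within the scatter of each other.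

The next compound to be measured is compound 4 `O=C(O)c1ccc(C(=O)Nc2cc(C(=O)O)cc(C(=O)O)c2)cc1` and it departs from compound 2 in one place. The change is carboxy in place of nitro on an aromatic carbon and in words it is carboxy in place of nitro on an aromatic carbon, para to a large group. Compound 2 already holds carboxy groups elsewhere in its structure.

For the measured compounds named here, no pair of measured compounds differs in one place alone, so the data give no direct measure of such a swap. Going by the values given here, the only anchor is compound 2 at 9.8 mg/kg and no step beyond the scatter is expected from it. The estimated change is a 1.2-fold lower number from compound 2 to compound 4 (0.09 log units; within the scatter) and its direction remains uncertain. Compound 4 is expected at 8 mg/kg with a range of 2.5 mg/kg to 25 mg/kg in this assay once it is measured.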

Compound 4, dose for 50% inhibition: 2.1 mg/kg
Compound 4: the middle estimate sits 3.8-fold (0.58 log units) above what was measured; the measured number lies below the stated range.
By their numbers in this assay, from the lowest: compounds 3, 4 and 1 (each within the scatter of the next); then compound 2.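

In this assay, the swap of nitro for carboxy on an aromatic carbon, para to a large group, gives a 4.7-fold lower number from compound 2 to compound 4 (0.67 log units; beyond the scatter), the first single change measured in this series. It shows that this position is sensitive to the group it carries: the two groups hold 3 heavy atoms each and differ in that carboxy brings 1 hydrogen-bond donor where nitro has 0, yet the step lies beyond the scatter, towards less compound being needed. This rests on a single pair of compounds, and no measurement at hand accounts for the step.

On these data alone, it remains open whether another group at this position, such as an amine, a methyl ester or a simple hydrogen, would give a number like that of compound 4 or one like that of compound 2, so the step cannot yet be tied to carboxy itself. As far as these compounds go, it is also open whether the swap would give a step of similar size if the two carboxy groups that compound 2 and compound 4 share elsewhere were replaced, for instance by methyl esters.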